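The compounds below may be only part of what the source reports. "The series", "measured", "known", "first", "only" and "open" are said of these compounds alone.

In an ADME assay on L6 cells (Rattus norvegicus) for cytotoxicity (a lower number here means a stronger inhibitor, a higher number a weaker inhibitor), three compounds built on one shared core have been measured so far. Compound 1 (`Cc1nc(-c2ccccn2)nc(N(C)C)c1Cl`), which carries a dimethylamino group, gives 115000 nM. Compound 2 (`Cc1nc(-c2ccccn2)nc(NCCCc2ccccc2)c1Cl`) gives 73500 nM, which lies within the scatter of compound 1. Compound 3 (`Cc1nc(-c2ccccn2)nc(NCC2CCCCC2)c1Cl`) gives 42400 nM, a lower number than compound 1 by more than the scatter. Compound 1 therefore sits at the high, weakly inhibiting end of this small set.

Compound 4 (`Cc1nc(-c2ccccn2)nc(NCC2CCOC2)c1Cl`) has not yet been measured. Moving to it from compound 1 makes one change: ((oxolan-3-yl)methyl)amino in place of dimethylamino on an aromatic carbon. The group ((oxolan-3-yl)methyl)amino thus takes the place of dimethylamino on an aromatic carbon.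

Compound 2 and compound 3 also have a larger amino group with a ring in that place, and both give numbers no higher than compound 1. Among the measured compounds shown here, the one measured step between them, a 1.7-fold lower number from compound 2 to compound 3 (0.24 log units; within the scatter), swaps the end of the chain and stays within the scatter. For the measured compounds named here, no measured compound has a five-membered non-aromatic ring there, so the range must stay wide.

In this assay, a small downward move that does not clearly exceed the scatter is expected. For compound 4 the estimated value is 70000 nM, with an expected range from 35000 nM to 130000 nM. This estimate means an expected 1.6-fold lower number from compound 1 to compound 4 (0.22 log units; within the scatter).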

Compound 4, half-maximal inhibitory concentration: 125000 nM
Compound 4: middle estimate off by 1.8-fold (0.25 log units), on the low side; measured number inside the range.
By their numbers in this assay, from the lowest: compounds 3, 2, 1 and 4 (each within the scatter of the next, the first and the last beyond it).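

In this assay the step of a 1.1-fold higher number from compound 1 to compound 4 (0.04 log units; within the scatter) shows that this aromatic carbon accepts the larger ((oxolan-3-yl)methyl)amino group, with its five-membered non-aromatic ring and a hydrogen-bond donor absent from dimethylamino, without a change in the number beyond the scatter. The chain-end comparisons add something new: the step of a 2.9-fold higher number from compound 3 to compound 4 (0.47 log units; beyond the scatter) is beyond the scatter and is modest in size, whereas the step of a 1.7-fold higher number from compound 2 to compound 4 (0.23 log units; within the scatter) stays within it. Among these compounds, then, a larger amino group does not by itself go with a lower number, since compound 3 stands beyond the scatter of compound 1 while compound 2 and compound 4 do not.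

Nothing available explains these numbers. A cyclopentyl group at the end of the same chain would help separate the effect of swapping the ring oxygen for carbon from that of going from a five-membered to a six-membered ring, and so show which of the two differences between compound 3 and compound 4 goes with the step between them.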